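The source may report more compounds than this note shows. Statements on the series, on what has been measured and on what is new or still open speak of the compounds shown alone.

Compound 1 `CC(C)CCn1nc(C2CCCCC2)c(O)c(C2=NS(=O)(=O)c3cc(NS(C)(=O)=O)ccc3N2)c1=O`: > 1000 nM, a limit.
Compound 2 `CC(C)CCn1nc(C2=CCCC2)c(O)c(C2=NS(=O)(=O)c3cc(NS(C)(=O)=O)ccc3N2)c1=O`: > 1000 nM, a limit.

Both entries come from an ADME assay on Huh-7 cells (Homo sapiens) for cytotoxicity, with a stated time of 72 h; a higher number here means that more compound is tolerated, a lower number that less compound is tolerated. Compound 2 stands only at a limit and has no number, and the evidence so far is the limit of > 1000 nM in this assay, at which 2 of the 2 values shown sit.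

Compound 3 `CC(C)CCn1nc(CC(C)C)c(O)c(C2=NS(=O)(=O)c3cc(NS(C)(=O)=O)ccc3N2)c1=O` carries isobutyl in place of the cyclopent-1-en-1-yl of compound 2, on an aromatic carbon next to the ring nitrogen: isobutyl in place of cyclopent-1-en-1-yl on an aromatic carbon. For the measured compounds named here, one measured step bears on this, since it also exchanges the group on an aromatic carbon, cyclopent-1-en-1-yl for cyclohexyl, but it has no readable size. Going by the values given here, with a step that the two limits leave unreadable from compound 1 to compound 2 as the only guide, no step beyond the scatter and no direction is expected in this assay.

The expected change is a step that the limit leaves unreadable from compound 2 to compound 3. For compound 3 the estimate is 1500 nM, with an expected range from 800 nM to 5000 nM, and a further limit is the likeliest report.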

Compound 3, half-maximal cytotoxic concentration: > 1000 nM
Compound 3: a limit, no number; the forecaster's own chance of this, stated with the estimate: 85%; the middle value is on the limit's open side.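

Compound 3 stays at a limit in this assay, as do compound 1 and compound 2, so no step among the three can be read: the limit of > 1000 nM in this assay, at which 3 of the 3 values shown sit.

The compounds shown leave open whether exchanging the group on the aromatic carbon changes this read-out at all.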